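The source may hold more compounds than are shown below. What is called first, only, known or untested is meant among the compounds shown, and "the series" means these compounds.

Measured compounds:
compound 1, `C[C@@H]1CN(c2cccc3c2C[C@H](CN(C)[C@H]2CCCc4cccnc42)NC3)C[C@H](C)N1`, with 61 nM
compound 2, `Cc1cnc(CN(C)C[C@H]2Cc3c(cccc3N3CCNCC3)CN2)c(C)c1`, with 21.4 nM
compound 3, `c1cnc2c(c1)CCC[C@@H]2N(CC1CCCCC1)C[C@H]1Cc2c(cccc2N2CCNCC2)CN1`, with 715 nM

All three were tested in a functional assay on CCRF-CEM cells for antagonist activity at C-X-C chemokine receptor type 4 (Homo sapiens), read by calcium flux, with stated times of 25 min and 90 s; a lower number here means a stronger inhibitor, a higher number a weaker inhibitor. Among these three numbers compound 1 sits second highest: compound 2 gives a lower number, and that gap lies beyond the usual scatter, while compound 3 gives a much higher number, also well beyond the scatter. Compound 1 is therefore neither the strongest nor the weakest of the three inhibitors shown.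

The next compound, compound 4, `CN1CCN(c2cccc3c2C[C@H](CN(C)[C@H]2CCCc4cccnc42)NC3)CC1`, has not yet been measured. It differs from compound 1 in one place: 4-methylpiperazin-1-yl in place of 3,5-dimethylpiperazin-1-yl on an aromatic carbon. Both groups are six-membered non-aromatic rings with two hetero atoms, but the one entering carries no hydrogen-bond donor, whereas the one leaving carries one donor and two defined stereocentres.

Among the measured compounds shown here, no measured pair in this set isolates this particular change, so the step from compound 1 to compound 4 cannot be read off from the data. A change of this kind, on the same side of the shared core, is expected to move this assay only modestly, if at all. The expected outcome is a step of a 1.5-fold higher number from compound 1 to compound 4 (0.17 log units; within the scatter), most likely toward a somewhat higher number. Compound 4 is estimated to give about 90 nM, within a range of 30 nM to 270 nM.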

Compound 4, half-maximal inhibitory concentration: 29.6 nM
The estimate for compound 4 lay 3.0-fold (0.48 log units) above the measured number; the measured number lies below the stated range.
By their numbers in this assay, from the lowest: compounds 2 and 4 (each within the scatter of the next); then compound 1; then compound 3.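

In this assay, placing 4-methylpiperazin-1-yl instead of 3,5-dimethylpiperazin-1-yl on this aromatic carbon gives a 2.1-fold lower number from compound 1 to compound 4 (0.31 log units; beyond the scatter), the only step shown here in which a single place changes. At this position, then, inhibition is kept, and modestly improved, by a group with no hydrogen-bond donor and no defined stereocentres, so neither feature of the leaving group is required for activity. Nothing available explains why the number moves in this direction.

The two groups differ in their donor count, stereocentres and methyl placement all at once, so the contribution of each remains unresolved. On these data alone, how a morpholin-4-yl ring or an open-chain dimethylamino group would behave on this aromatic carbon also remains open.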